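The source may report more compounds than this note shows. Statements on the series, on what has been measured and on what is new or still open speak of the compounds shown alone.

Among the compounds with values here, in a functional assay for inhibition, with Rattus norvegicus as the target (on this read-out higher numbers stand for weaker inhibition and lower numbers for stronger inhibition), compound 1 (`CC(C)(C)/N=c1\c(O)c(O)\c1=N/Cc1cccnc1`) gives 2600 nM and sits at the weaker end of the three compounds measured so far. Compound 2 (`CCC(C)(C)/N=c1\c(O)c(O)\c1=N/Cc1ccc(F)cc1Cl`) gives 1500 nM and that lies within the usual scatter of compound 1. Compound 3 (`CCc1cc(Br)ccc1C/N=c1\c(O)c(O)\c1=N/C(C)(C)C`) gives 270 nM as a clearly lower number than compound 1, which means stronger inhibition. Compound 4 (`CC(C)(C)/N=c1\c(O)c(O)\c1=N/Cc1ccccn1`) keeps the atoms of compound 1 but joins them differently (pyridin-2-yl in place of pyridin-3-yl on a saturated chain carbon bound to a double-bonded nitrogen) with pyridin-2-yl in place of pyridin-3-yl on a saturated chain carbon bound to a double-bonded nitrogen. Within the data shown here, no measured pair shows this swap alone. In this assay only a small change (a 1.2-fold higher number from compound 1 to compound 4 (0.06 log units; within the scatter)) is expected, probably within the scatter and without a sure direction. The estimate for compound 4 is 3000 nM (expected range 900 nM to 10000 nM).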

Compound 4, half-maximal inhibitory concentration: 11500 nM
For compound 4 the middle estimate is 3.8-fold (0.58 log units) below the measured one; measured number outside the range, above it.
By their numbers in this assay, from the lowest: compound 3; then compounds 2 and 1 (each within the scatter of the next); then compound 4.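

Pyridin-2-yl in place of pyridin-3-yl on a saturated chain carbon bound to a double-bonded nitrogen gives in this assay a 4.4-fold higher number from compound 1 to compound 4 (0.65 log units; beyond the scatter), which means weaker inhibition. The atoms and the counted hydrogen-bond donors and acceptors stay the same, so this position responds to how the pyridine is joined, not only to which atoms are present. No measurement here explains the difference. Still open, from the compounds shown here alone, is how pyridin-4-yl at this position would compare, and whether the same swap has a similar effect with other groups on the shared core.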